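The source may hold more compounds than are shown below. What is called first, only, known or untested is meant among the compounds shown, and "the series" means these compounds.

In a functional assay on HeLa cells (Homo sapiens) for cytotoxicity, read by MTT assay (a lower number here means a stronger inhibitor, a higher number a weaker inhibitor), compound 1 `CCCCCCC(C)(O)CC(=O)O[C@H](CC=C(C)C)C1=CC(=O)c2c(O)ccc(O)c2C1=O` gives > 100000 nM, which is a limit of the assay and not a number. Compound 2 `CCCCC(C)(O)CC(=O)O[C@H](CC=C(C)C)C1=CC(=O)c2c(O)ccc(O)c2C1=O` gives 60600 nM, and compound 3 `CC(C)=CC[C@@H](OC(=O)C1CCCOC1)C1=CC(=O)c2c(O)ccc(O)c2C1=O` gives 60500 nM, so these two measured numbers stand level within the scatter. Compound 4 `CC(C)=CC[C@@H](OC(=O)c1ccoc1)C1=CC(=O)c2c(O)ccc(O)c2C1=O` keeps the shared core and changes the ester group: furan-3-yl in place of oxan-3-yl on a carbonyl carbon. In words, furan-3-yl stands in place of oxan-3-yl on a carbonyl carbon. Two measured steps change the group at this same place. The first is a 1.0-fold lower number from compound 2 to compound 3 (0.00 log units; within the scatter), and the second, which rests on a limit, is an at least 1.6-fold lower number from compound 1 to compound 3 (0.21 log units; that floor lies within the scatter). Among the measured compounds shown here, neither goes beyond the scatter, although none of the measured esters carries an aromatic ring there, so the evidence for this change is indirect. A small shift at most is therefore expected in this assay. The expected change is a 1.3-fold lower number from compound 3 to compound 4 (0.13 log units; within the scatter), which would not clearly exceed the scatter. Compound 4 is estimated at 45000 nM, with an expected range of 15000 nM to 100000 nM.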

Compound 4, half-maximal inhibitory concentration: > 100000 nM
Compound 4: a limit, no number (the forecaster's own chance of this, stated with the estimate: 15%); middle value at least 2.2-fold (0.34 log units) away from the limit.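

Among the four esters shown, compound 4 alone carries an aromatic ring on this carbonyl carbon, and in this assay its reading is a limit and not a number: the limit of > 100000 nM in this assay, at which 2 of the 4 values shown sit. Putting furan-3-yl in place of oxan-3-yl gives an at least 1.6-fold higher number from compound 3 to compound 4 (0.21 log units; that floor lies within the scatter), and the comparison with the open chain gives an at least 1.6-fold higher number from compound 2 to compound 4 (0.21 log units; that floor lies within the scatter), so the aromatic ring brought no gain towards a stronger inhibitor, yet neither floor shows a shift beyond the scatter. The step between compound 1 and compound 4 cannot be read, as both values are limits.

From the compounds shown here alone, how far the true value of compound 4 lies past its limit remains open, and with it the real size of this change. Also open, going by these compounds, is whether a phenyl ring or an amine such as piperidin-3-yl at this place would read like furan-3-yl or like oxan-3-yl.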